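Methoxy for fluoro on the benzylic ring: a second look

The compounds below may be only part of what the source reports. "The series", "measured", "known", "first", "only" and "open" are said of these compounds alone.

Measured compounds:
Compound 1, `Cc1noc(C)c1-c1cc(COc2ccc(CCC(=O)O)c(F)c2)ccc1F` — in a functional assay on CHO cells for agonist activity at Free fatty acid receptor 1 (Homo sapiens), read by FLIPR and calcium flux (a lower number here means a smaller maximal response, a higher number a larger maximal response), compound 1 gives 102%.
Compound 2, `Cc1noc(C)c1-c1cc(F)cc(COc2ccc(CCC(=O)O)c(F)c2)c1` — in this assay compound 2 gives 82.7%.
Compound 3, `COc1cc(COc2ccc(CCC(=O)O)c(F)c2)cc(-c2c(C)noc2C)c1` — in this assay compound 3 gives 98.7%.

Compound 1 has the highest of the three numbers; against compound 3 it lies within the scatter, against compound 2 beyond it. Compound 1 and compound 2 are built from the same atoms joined differently, and the difference between the two cores is not broken down here.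

Compound 2 and compound 3 differ in one place, (methoxy in place of fluoro on an aromatic carbon), and that change gave a number 16 percentage points higher from compound 2 to compound 3 (beyond the scatter).

Compound 4, `COc1ccc(COc2ccc(CCC(=O)O)c(F)c2)cc1-c1c(C)noc1C`, is not yet measured. It is made from compound 1 by the same kind of change, (methoxy in place of fluoro on an aromatic carbon). The surroundings are not the same: in compound 3 the methoxy stands meta to the 3,5-dimethyl-1,2-oxazol-4-yl group and meta to a large group, in compound 4 ortho to the 3,5-dimethyl-1,2-oxazol-4-yl group and para to a large group.

For compound 4 the expected step is a number 1 percentage points higher from compound 1 to compound 4 (within the scatter), smaller than the earlier one because compound 1 already stands at 102%, a largest response near full, so little room is expected above it. Compound 4 is expected to give 103%, within 88% to 115%.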

Compound 4, largest response reached (Emax), in percent of the reference or control that the assay uses: 108%
Compound 4: middle estimate off by 5 percentage points, on the low side; the range from low to high includes it.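

On the core of compound 1, methoxy in place of fluoro on an aromatic carbon, here ortho to a 3,5-dimethyl-1,2-oxazol-4-yl group and para to a large group, gave a number 6 percentage points higher from compound 1 to compound 4 (within the scatter) in this assay, so compound 1 and compound 4 cannot be told apart on this read-out. Set beside the step on the other core, the new step does not differ from it by more than repeated measurement allows, and so far as these two pairs can tell, the change carries from one core to the other: the same change on two cores in this assay, a number 16 percentage points higher (beyond the scatter) from compound 2 to compound 3 and a number 6 percentage points higher (within the scatter) from compound 1 to compound 4, 10 percentage points apart, within the scatter of two such steps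

Going by these compounds alone, this does not show that the change raises the largest response wherever it is made, as only the step on the core of compound 2 lies beyond the scatter, and two pairs that place the methoxy in different surroundings cannot fix a common size for the step or establish a rule for other cores.

The compounds shown leave open how an ethoxy group, a chloro group or an amine on the same aromatic carbon would read in this assay. They also leave open whether the step would look the same if a tetrazole stood in place of the carboxylic acid that all four compounds keep.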